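Notes on compound 4: aryl change on an aromatic nitrogen

A few compounds are considered here, and "the series" means these few. Any claim that something is new, unique, unknown or untested is made for them only; others in the source may bear on it.

Of the compounds shown here, three have been measured in a functional assay on HepG2 cells (Homo sapiens) for cytotoxicity, read by MTT assay, with a stated time of 72 h; on this read-out higher numbers stand for weaker inhibition and lower numbers for stronger inhibition. Compound 1 `COc1ccc(-n2ccc(=O)c(C(=O)Nc3ccc(Oc4ccnc5c4ccn5C)c(F)c3)n2)cc1` reaches only the limit of this assay, giving > 60000 nM. Compound 2 `Cc1cc(=O)n(-c2ccc(F)cc2)nc1C(=O)Nc1ccc(Oc2ncnc3[nH]ccc23)cc1` likewise gives a limit, > 60000 nM. Going by the values given here, compound 3 `Cc1cc(=O)n(-c2ccc(F)cc2)nc1C(=O)Nc1ccc(Oc2ncnc3[nH]ccc23)c(F)c1` is the one compound with a number, giving 12900 nM in this assay. Among the compounds with values here, the single step that can be measured, an at least 4.6-fold lower number from compound 2 to compound 3 (0.66 log units; beyond the scatter), corresponds to fluoro in place of hydrogen on an aromatic carbon and is only a minimum because the limit of > 60000 nM in this assay, at which 2 of the 3 values shown sit, caps what can be said about compound 2.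

Compound 4 `Cc1cc(=O)n(-c2cccc(C(F)(F)F)c2)nc1C(=O)Nc1ccc(Oc2ncnc3[nH]ccc23)c(F)c1` differs from compound 3 at another position: 3-(trifluoromethyl)phenyl in place of 4-fluorophenyl on an aromatic nitrogen. Within the data shown here, no measured pair in the set differs at this position, so none of the measured steps bears on it; the step from compound 2 to compound 3 concerns fluoro in place of hydrogen on an aromatic carbon, a feature that compound 4 shares with compound 3. In this assay the change is therefore expected to give no step beyond the scatter, a 1.0-fold higher number from compound 3 to compound 4 (0.00 log units; within the scatter). Compound 4 is estimated at 13000 nM, with a range from 4000 nM to 45000 nM.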

Compound 4, half-maximal inhibitory concentration: 26300 nM
Estimate against measurement, compound 4: 2.0-fold (0.31 log units) below; the range from low to high includes it.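

Going by these compounds alone, the aryl group on the aromatic nitrogen is the first position where a change of substituent on that aryl ring can be read directly, and in this assay it is not neutral: the exchange gives a 2.0-fold higher number from compound 3 to compound 4 (0.31 log units; beyond the scatter). The earlier step concerned fluoro in place of hydrogen on an aromatic carbon, so it said nothing about this position; here that fluoro group is common to both compounds and the change stands alone. The step is modest and compound 4 still gives a number rather than a limit, so on this core the position takes 3-(trifluoromethyl)phenyl, with 10 heavy atoms against 7 for 4-fluorophenyl, without the read-out reaching the end of its range.

The exchange alters both the substituent and its place on the phenyl ring, so one step cannot separate the two, and plain phenyl or a phenyl ring carrying an amine or a carboxylic acid would be needed to show how far the trend holds. Neither compound 1 nor compound 2 adds a number at this position, and how much further the values can rise remains capped: the limit of > 60000 nM in this assay, at which 2 of the 4 values shown sit.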